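Methyl for 2-fluorophenyl on a carbonyl carbon

The source may report more compounds than this note shows. Statements on the series, on what has been measured and on what is new or still open speak of the compounds shown alone.

compound 1 `CSCC(=O)N1CCN(c2nc(=O)c3cc(C(F)(F)F)cc([N+](=O)[O-])c3s2)CC1` gives 15.2 ug/mL
compound 2 `O=C(c1ccccc1F)N1CCN(c2nc(=O)c3cc(C(F)(F)F)cc([N+](=O)[O-])c3s2)CC1` gives 3.1 ug/mL
compound 3 `O=C(c1ccc(Cl)cc1)N1CCN(c2nc(=O)c3cc(C(F)(F)F)cc([N+](=O)[O-])c3s2)CC1` gives 5.19 ug/mL

In a physicochemical assay for solubility, read by HPLC (a lower number here means a less soluble compound, a higher number a more soluble compound), compound 2 stands at 3.1 ug/mL and shares the low end of the three numbers with compound 3 (a 1.7-fold higher number from compound 2 to compound 3 (0.22 log units; within the scatter)). Compound 4 `CC(=O)N1CCN(c2nc(=O)c3cc(C(F)(F)F)cc([N+](=O)[O-])c3s2)CC1` carries methyl in place of 2-fluorophenyl on a carbonyl carbon. Two modest measured steps bear on this: a 4.9-fold lower number from compound 1 to compound 2 (0.69 log units; beyond the scatter) with 2-fluorophenyl entering, and a 2.9-fold lower number from compound 1 to compound 3 (0.47 log units; beyond the scatter) with 4-chlorophenyl entering. Among the measured compounds shown here, compound 1 is the only measured compound without an aromatic ring on that carbonyl carbon, and compound 4 also lacks one. Read in reverse, those steps suggest a rise, and the expected size is a 5.8-fold higher number from compound 2 to compound 4 (0.76 log units; beyond the scatter) as estimated here. For compound 4 the estimated value is 18 ug/mL with an expected range from 7 ug/mL to 45 ug/mL in this measurement.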

Compound 4, solubility: 83.9 ug/mL
For compound 4 the middle estimate is 4.7-fold (0.67 log units) below the measured one; measured number outside the range, above it.
By their numbers in this assay, from the lowest: compounds 2 and 3 (each within the scatter of the next); then compound 1; then compound 4.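

Methyl on the carbonyl carbon gives the highest number of the four compounds in this assay, with a 27-fold higher number from compound 2 to compound 4 (1.43 log units; beyond the scatter) and a 16-fold higher number from compound 3 to compound 4 (1.21 log units; beyond the scatter). Losing the aromatic ring is not the whole change, since hydrogen in place of methylsulfanyl on the saturated chain carbon also counts, with a 5.5-fold higher number from compound 1 to compound 4 (0.74 log units; beyond the scatter). No measurement given here accounts for these steps. On these data alone, whether an amine, a carboxylic acid or a longer chain at that saturated carbon would keep the number of compound 4 remains open.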